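The source may report more compounds than this note shows. Statements on the series, on what has been measured and on what is new or still open speak of the compounds shown alone.

Within the data shown here, in a functional assay on cells (T-cell line, Homo sapiens) for inhibition (on this read-out higher numbers stand for weaker inhibition and lower numbers for stronger inhibition), compound 2 (`CCCCN1CCC(COC(c2ccccc2)c2ccccc2)CC1`) stands at 14000 nM, the highest of the two numbers so far, and its only neighbour, compound 1 (`COc1ccccc1CCCN1CCC(COC(c2ccccc2)c2ccccc2)CC1`), gives 2400 nM. Compound 3 (`CCCCCCN1CCC(COC(c2ccccc2)c2ccccc2)CC1`) differs from compound 2 at the far end of the chain: ethyl in place of hydrogen on a saturated chain carbon, four bonds along the chain from an amine nitrogen in a ring. Among the measured compounds shown here, one measured step bears on this place: a 5.8-fold higher number from compound 1 to compound 2 (0.77 log units; beyond the scatter), with methyl in place of 2-methoxyphenyl on the same chain. For the measured compounds named here, no measured pair tests plain lengthening of the chain, so this evidence is indirect. The step does show that the number in this assay moves with what the chain carries. A modest move towards a lower number is expected, smaller than that measured step, and the estimated size is a 2.3-fold lower number from compound 2 to compound 3 (0.37 log units; beyond the scatter) (a change that may prove little more than the scatter). Compound 3 is estimated at 6000 nM (expected range 2500 nM to 14000 nM).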

Compound 3, half-maximal inhibitory concentration: 5500 nM
Compound 3: middle estimate off by 1.1-fold (0.04 log units), on the high side; the range from low to high includes it.
By their numbers in this assay, from the lowest: compound 1; then compound 3; then compound 2.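

In this assay, length alone counts at this place: the chain stays free of any aryl group, and ethyl in place of hydrogen gives a 2.5-fold lower number from compound 2 to compound 3 (0.41 log units; beyond the scatter) with no other change, which the earlier pair could not separate from the loss of 2-methoxyphenyl. Extension of the plain chain closes only part of the distance to the aryl-bearing chain, since propyl in place of 2-methoxyphenyl still gives a 2.3-fold higher number from compound 1 to compound 3 (0.36 log units; beyond the scatter) on the shared core. No supporting measurement bears on why the number moves with this change.

From the compounds shown here alone, whether a longer chain, such as octyl, keeps lowering the number or reverses the direction remains open. Also open, going by these compounds, is what a chain ending in plain phenyl, an amine or a carboxylic acid would give in this assay on the same core.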